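The compounds below may be only part of what the source reports. "The series", "measured", "known", "first", "only" and "open" are said of these compounds alone.

Compound 1 `Cc1cc(NCc2ccccn2)n2ncc(-c3ccc(F)cc3)c2n1` was examined in a physicochemical assay for solubility, read by HPLC, using the shake flask method, measured as kinetic solubility, with a stated time of 2 h, at pH 7.4; a lower number here means a less soluble compound, a higher number a more soluble compound. In this assay compound 1 gives < 5000 nM, which is a limit of the assay rather than a number. Two companions sketch the range seen so far. Compound 2 `Cc1cc(NCc2ccncc2)n2nc(C)c(-c3ccccc3)c2n1` gives 134000 nM in this assay. Compound 3 `Cc1cc(NCc2ccc3ccccc3n2)n2nc(C)c(-c3ccccc3)c2n1` gives < 5000 nM in this assay, again a limit. Most of what has been measured here sits at the limit of < 5000 nM in this assay, at which 2 of the 3 values shown sit. Compound 4 `Cc1cc(NCc2ccccn2)n2ncc(-c3ccc(F)cc3F)c2n1` differs from compound 1 by a single change, (fluoro in place of hydrogen on an aromatic carbon). Among the measured compounds shown here, no measured pair separated by exactly this change exists, so the expectation rests on compound 1 alone. The step that the limit leaves unreadable from compound 1 to compound 4 is expected to stay within the usual scatter. Compound 4 is estimated at 3000 nM, with a range from 800 nM to 7000 nM.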

Compound 4, solubility: < 5000 nM
Compound 4 gave a limit, no number; the forecaster's own chance of this, stated with the estimate: 80%; the middle value does not contradict the limit.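

Among the compounds shown here, compound 1 and compound 4 each give only a limit of the assay, not a number, so no step between them can be read. The compounds shown leave open what fluoro in place of hydrogen does in this assay, with most values resting on one limit: the limit of < 5000 nM in this assay, at which 3 of the 4 values shown sit.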